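Allyl for cyanomethyl on the aniline nitrogen of compound 1

A few compounds are considered here, and "the series" means these few. Any claim that something is new, unique, unknown or untested is made for them only; others in the source may bear on it.

Compound 1 `Cc1nc2ccc(CN(CC#N)c3ccc(C(=O)N[C@@H](CCC(=O)O)C(=O)O)c(F)c3)cc2c(=O)[nH]1` gives the lower of the two numbers seen so far in an assay on isolated protein for inhibition of Thymidylate synthase (Mus musculus) (on this read-out lower numbers stand for stronger inhibition and higher numbers for weaker inhibition), with a value of 170 nM. Going by the values given here, the only other measured compound, compound 2 `Cc1nc2ccc(CNc3ccc(C(=O)N[C@@H](CCC(=O)O)C(=O)O)cc3F)cc2c(=O)[nH]1`, differs from it in more than one place and gives 9340 nM in this assay; those two values alone show a wide gap, but they do not isolate any single change.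

Compound 3 `C=CCN(Cc1ccc2nc(C)[nH]c(=O)c2c1)c1ccc(C(=O)N[C@@H](CCC(=O)O)C(=O)O)c(F)c1` keeps the shared core of compound 1 and changes one group: vinyl in place of cyano on a saturated chain carbon bound to a nitrogen on an aromatic ring. Read one bond further out, the change is cyanomethyl to allyl. Among the compounds with values here, no measured pair shows what this exchange does, so nothing on record fixes its size or direction. Without such a comparison the author expects the step from compound 1 to compound 3 to be small and not clearly beyond the scatter, on the order of a 1.5-fold higher number from compound 1 to compound 3 (0.17 log units; within the scatter). On that basis compound 3 is estimated at 250 nM in this assay, within a range from 80 nM to 800 nM, the breadth of that range reflecting the absence of any directly comparable step.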

Compound 3, half-maximal inhibitory concentration: 76 nM
Beside the measured number, compound 3's estimate is 3.3-fold (0.52 log units) above it; the whole stated range lies above it.
By their numbers in this assay, from the lowest: compound 3; then compound 1; then compound 2.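

In this assay, going by these compounds alone, putting vinyl in place of cyano on a saturated chain carbon bound to a nitrogen on an aromatic ring gives a 2.2-fold lower number from compound 1 to compound 3 (0.35 log units; beyond the scatter) and so provides the only comparison here that isolates a single change. The step is modest, but it is beyond the scatter and it runs toward stronger inhibition. For this pair, the nitrile with its one hydrogen-bond acceptor can therefore give way to a vinyl group with none, and the number does not rise. Nothing on record accounts for the size or direction of this step.

Compound 2 differs from compound 1 and compound 3 in more than one place, so the compounds shown leave open what either cyanomethyl or allyl contributes at this position on its own. Going by these compounds, it also remains open how a saturated propyl chain, a propargyl group or a longer chain ending in an amine would compare with allyl at this position.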